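Para Chloro for Para Methyl on the Outer Ring

A few compounds are considered here, and "the series" means these few. Any claim that something is new, unique, unknown or untested is made for them only; others in the source may bear on it.

Compound 1, `CCS(=O)(=O)c1ccc2nc(-c3ccc(-c4ccccc4F)cc3)[nH]c2c1`: in an assay on isolated protein for inhibition of acyl-CoA desaturase 1 (Rattus norvegicus) (a lower number here means a stronger inhibitor, a higher number a weaker inhibitor), compound 1 gives 1250 nM.
Compound 2, `CS(=O)(=O)c1ccc2nc(-c3ccc(-c4ccccc4)cc3)[nH]c2c1`: in this assay compound 2 gives 20 nM.
Compound 3, `Cc1ccc(-c2ccc(-c3nc4ccc(S(C)(=O)=O)cc4[nH]3)cc2)cc1`: in this assay compound 3 gives > 20000 nM, which is a limit of the assay and not a number.

Compound 3 stands at the weak end of the three, sitting at the limit of > 20000 nM in this assay, at which 1 of the 3 values shown sits. Among the compounds with values here, the one measured step that speaks to its outer ring is an at least 1000-fold higher number from compound 2 to compound 3 (3.00 log units; beyond the scatter), a large loss from the introduction of a single methyl. Compound 4, `CS(=O)(=O)c1ccc2nc(-c3ccc(-c4ccc(Cl)cc4)cc3)[nH]c2c1`, differs from compound 3 by chloro in place of methyl on an aromatic carbon. Within the data shown here, no measured compound carries chloro, so the only guide is that a single heavy atom para to a large group, in the one case seen, turned a strong inhibitor into one beyond the limit. Chloro is again a single heavy atom at the same place, and compound 4 is therefore expected to remain weak, though perhaps within reach of a number rather than a limit. The estimate for compound 4 in this assay is 6000 nM, with a range from 600 nM to 40000 nM. The step expected from that estimate is an at least 3.3-fold lower number from compound 3 to compound 4 (0.52 log units; beyond the scatter).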

Compound 4, half-maximal inhibitory concentration: > 20000 nM
Compound 4 ended at the assay's limit; the forecaster's own chance of this, stated with the estimate: 35%; middle value at least 3.3-fold (0.52 log units) away from the limit.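

Chloro in place of hydrogen gives an at least 1000-fold higher number from compound 2 to compound 4 (3.00 log units; beyond the scatter) in this assay, so the large loss seen with methyl is not peculiar to that one group. Two different single heavy atoms on this aromatic carbon, para to a large group, now share the same outcome, and only hydrogen, in compound 2, gives a measurable number at this place. The step between methyl and chloro cannot be read, and the values of compound 3 and compound 4 are both limits of the assay, not numbers: the limit of > 20000 nM in this assay, at which 2 of the 4 values shown sit.

Which of methyl and chloro costs more remains unknown. From the compounds shown here alone, it also remains open whether a group such as a hydroxyl or an amine on this carbon would keep inhibition within a measurable range.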